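This account rests on a few compounds, and the source may have more. Where it says the series, first, only, none or still open, it means among the compounds named here.

Two compounds of the series have so far been run in a functional assay on CHO cells for agonist activity at Free fatty acid receptor 1 (Homo sapiens), read by FLIPR and calcium flux, tested at 100 nM; a higher number here means a stronger effect of the compound at the concentration tested, a lower number a weaker effect. Compound 1 `O=C(O)CC1COc2cc(OCc3nnc(-c4ccccc4)s3)ccc21` gives 3.36% in this assay. Compound 2 `Cc1nc(-c2ccsc2)sc1COc1ccc2c(c1)OCC2CC(=O)O` gives 56.5%, the higher of the two numbers on hand. The gap between compound 2 and compound 1 lies beyond the scatter of repeat measurements. Compound 2 is the stronger of the pair at this concentration. Compound 3 `Cc1ccc(-c2nc(C)c(COc3ccc4c(c3)OCC4CC(=O)O)s2)cc1` has not yet been measured in this assay. It differs from compound 2 in one place: 4-methylphenyl in place of thiophen-3-yl on an aromatic carbon Both groups are aromatic and of comparable size. Among the compounds with values here, no step between two measured compounds is available to calibrate this kind of exchange, so the expectation for compound 3 rests only on compound 2 and the change itself. In this assay the step of a number 1.5 percentage points higher from compound 2 to compound 3 (within the scatter) is expected to be small, within the scatter, with no firm direction. For compound 3 the estimate in this assay is 58%, with a range from 30% to 85%, because compound 2 gives 56.5% and the change is modest.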

Compound 3, a percentage reported as activity, at one concentration (the size of the read-out at that concentration, not a potency): 54.9%
Compound 3: middle estimate off by 3.1 percentage points, on the high side; the measured number falls inside the stated range.
By their numbers in this assay, from the lowest: compound 1; then compounds 3 and 2 (each within the scatter of the next).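

In this assay, within the data shown here, replacing thiophen-3-yl with 4-methylphenyl gives a number 1.6 percentage points lower from compound 2 to compound 3 (within the scatter), the only step on hand for a change at this aromatic carbon of the five-membered aromatic ring with 1 nitrogen and 1 sulfur. For this pair, the read-out stays within the scatter when a five-membered aromatic ring with 1 hetero atom and 5 heavy atoms gives way to a six-membered aromatic ring of carbon only with 7 heavy atoms. The data on hand give no explanation for the close agreement of the two compounds.

On these data alone, it remains open whether a pyridine ring or a saturated cyclohexyl group at this carbon would keep the read-out at this level. Compound 1 differs from both compounds in more than one place, and these data tie its number to no single part.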